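The source may report more compounds than this note shows. Statements on the series, on what has been measured and on what is new or still open speak of the compounds shown alone.

Measured compounds and their values in a functional assay on MCF7 cells (Homo sapiens) for inhibition, read by MTT assay, with a stated time of 48 h; on this read-out higher numbers stand for weaker inhibition and lower numbers for stronger inhibition:
compound 1, `CCOC(=O)C1=C(N)Nc2[nH]nc(C)c2C1c1ccc(N(C)C)cc1`, gives 5060 nM
compound 2, `CCOC(=O)C1=C(N/C=N/c2ccc(C)cc2)Nc2[nH]nc(C)c2C1c1ccc(N(C)C)cc1`, gives 50500 nM
compound 3, `CCOC(=O)C(=NNC1=C(C(=O)OCC)C(c2ccc(N(C)C)cc2)c2c(C)n[nH]c2N1)C(=O)OCC`, gives 89800 nM

Compound 3 holds the highest number of the three. Its nearest neighbour is compound 2, as a 1.8-fold higher number from compound 2 to compound 3 (0.25 log units; within the scatter); its furthest is compound 1, as an 18-fold higher number from compound 1 to compound 3 (1.25 log units; beyond the scatter). The other step from the unsubstituted amine, a 10-fold higher number from compound 1 to compound 2 (1.00 log units; beyond the scatter), points the same way: both substituents on this amine nitrogen raise the number well beyond the scatter, while the exchange of one substituent for the other in this assay moves it only within the scatter.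

Compound 4, `CCOC(=O)C1=C(N/N=C(/C#N)C(=O)OCC)Nc2[nH]nc(C)c2C1c1ccc(N(C)C)cc1`, is not yet measured in this assay. It differs from compound 3 thus:
a group of 9 heavy atoms (5 carbon, 2 nitrogen, 2 oxygen; no ring) in place of a group of 12 heavy atoms (7 carbon, 1 nitrogen, 4 oxygen; no ring), on an amine nitrogen

The step that bears on this change is the substituent exchange on the same amine nitrogen, a 1.8-fold higher number from compound 2 to compound 3 (0.25 log units; within the scatter), which stayed within the scatter. Going by the values given here, no step here removes the substituent altogether, so the change from compound 3 to compound 4 is expected to stay within the scatter too, with no clear direction. The number for compound 4 in this assay is therefore estimated at 60000 nM, in a range from 20000 nM to 180000 nM. The expected step is a 1.5-fold lower number from compound 3 to compound 4 (0.18 log units; within the scatter).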

Compound 4, half-maximal inhibitory concentration: 35600 nM
Compound 4: middle estimate off by 1.7-fold (0.23 log units), on the high side, and the stated range covers the measured number.
By their numbers in this assay, from the lowest: compound 1; then compounds 4, 2 and 3 (each within the scatter of the next, the first and the last beyond it).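

In this assay, exchanging one substituent for another on this amine nitrogen can move the number beyond the scatter (a 2.5-fold lower number from compound 3 to compound 4 (0.40 log units; beyond the scatter)), so the substituents are not interchangeable here, as the exchange between compound 2 and compound 3 alone had suggested; in this step, the group with a nitrile and one ethyl ester replaces the group with two ethyl esters. The two groups of 9 heavy atoms, one with a six-membered aromatic ring and one with no ring, stay within the scatter of each other (a 1.4-fold lower number from compound 2 to compound 4 (0.15 log units; within the scatter)), so the ring-free group with the nitrile cannot be separated from the aromatic one in this assay. Against the free amine, the new group still carries a cost beyond the scatter (a 7.0-fold higher number from compound 1 to compound 4 (0.85 log units; beyond the scatter)), which makes three substituents out of three on this nitrogen with higher numbers than compound 1, and none of the compounds shown goes against this.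

Nothing shown gives a reason for any of these steps. On these data alone, whether a methyl or acetyl group on this amine nitrogen would stay close to compound 1 (5060 nM) remains open, as does whether a substituent with a nitrile in place of both ethyl esters would extend the step seen with compound 4.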